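The source may hold more compounds than are shown below. What is called first, only, known or untested is meant among the compounds shown, and "the series" means these compounds.

Compound 1 (`CCC(=O)N(c1ccc(C)cc1)C1CCCCC1N(C)C`) gives > 50 mg/kg as a limit of the assay
Compound 2 (`CCC(=O)N(c1cccc(C(F)(F)F)c1)C1CCCC1N(C)C`) gives 0.3 mg/kg
Compound 3 (`CCC(=O)N(c1ccc(Cl)c(Cl)c1)C1CCCC1N`) gives 0.02 mg/kg

In a functional assay on the whole organism for positive allosteric modulation, with Mus musculus as the target (on this read-out lower numbers stand for an effect already at smaller amounts and higher numbers for an effect only at larger amounts of compound), compound 3 has the lower of the two actual numbers, and compound 2 lies higher by a gap beyond the usual scatter. The entry for compound 1 is a limit and not a number.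

Compound 4 (`CCC(=O)N(c1ccc(Cl)c(Cl)c1)C1CCCC1N(C)Cc1ccccc1`) departs from compound 3 in one place: benzyl(methyl)amino in place of amino on a saturated ring carbon with benzyl(methyl)amino in place of amino on a saturated ring carbon. Among the measured compounds shown here, no measured pair isolates this change, since compound 2 at 0.3 mg/kg and compound 3 at 0.02 mg/kg differ in more than one place. The expectation is therefore loose. Compound 3 at 0.02 mg/kg sits so low that a large replacement is expected to move the number upward in this assay rather than downward, and by more than the scatter. The expected move is a 50-fold higher number from compound 3 to compound 4 (1.70 log units; beyond the scatter) and remains an estimate. For compound 4 the estimated value is 1 mg/kg (range 0.08 mg/kg to 20 mg/kg).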

Compound 4, dose for half-maximal effect: 0.2 mg/kg
Beside the measured number, compound 4's estimate is 5.0-fold (0.70 log units) above it; measured number inside the range.
By their numbers in this assay, from the lowest: compound 3; then compounds 4 and 2 (each within the scatter of the next). At a limit, above all of these: compound 1.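

In this assay, placing benzyl(methyl)amino in place of amino on a saturated ring carbon of the five-membered ring gives a 10-fold higher number from compound 3 to compound 4 (1.00 log units; beyond the scatter), and this is the first step shown that isolates a change at this position. The step shows that this place accepts a much larger group carrying an aromatic ring and no hydrogen-bond donor, at a real cost, yet compound 4 still gives a measured number of 0.2 mg/kg rather than a limit. Nothing at hand bears on why the step has this size.

The compounds shown leave open how the number moves on the same core with methylamino or benzylamino at this carbon, and so which part of benzyl(methyl)amino carries the step. Also open, on these data alone, is how a phenethyl group on this nitrogen would read.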